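A few compounds are considered here, and "the series" means these few. Any claim that something is new, unique, unknown or untested is made for them only; others in the source may bear on it.

Compound 1 `O=C(NC(=S)NNc1ncnc2ccccc12)c1ccc(F)cc1`: in a functional assay on CNE-2 cells (Homo sapiens) for cytotoxicity, read by MTT assay, with a stated time of 72 h (a lower number here means a stronger inhibitor, a higher number a weaker inhibitor), compound 1 gives 2840 nM.
Compound 2 `O=C(NC(=S)NNc1ncnc2ccccc12)c1ccc(Cl)cc1`: in this assay compound 2 gives 1530 nM.

Among the compounds with values here, of these two numbers, that of compound 2 is the lower, yet the only step, a 1.9-fold lower number from compound 1 to compound 2 (0.27 log units; within the scatter), lies within the scatter, so no order between the two is claimed. Compound 3 `O=C(NC(=S)NNc1ncnc2ccccc12)c1ccc(C(F)(F)F)cc1` differs from compound 2 by trifluoromethyl in place of chloro on an aromatic carbon. Within the data shown here, the one measured step, chloro in place of fluoro on an aromatic carbon, bears on this change and did not rise above the scatter. In this assay the estimated step of a 1.2-fold lower number from compound 2 to compound 3 (0.07 log units; within the scatter) is expected to stay within the scatter. The estimate for compound 3 is 1300 nM, between 450 nM and 4000 nM.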

Compound 3, half-maximal inhibitory concentration: 22500 nM
Estimate against measurement, compound 3: 17-fold (1.24 log units) below; measured number above the stated range.
By their numbers in this assay, from the lowest: compounds 2 and 1 (each within the scatter of the next); then compound 3.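

In this assay trifluoromethyl gives a 15-fold higher number from compound 2 to compound 3 (1.17 log units; beyond the scatter) and a 7.9-fold higher number from compound 1 to compound 3 (0.90 log units; beyond the scatter) and so, unlike the step between the two halogens, clears the scatter. The group on this aromatic carbon, para to a large group, can therefore move the number substantially, here towards a weaker inhibitor against either halogen. The compounds shown leave open where a methyl, a methoxy or an amine at this place would fall, and whether any group here gives a number clearly lower than those of compound 1 and compound 2. Nothing at hand says why this step is so large.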